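The source may hold more compounds than are shown below. What is called first, only, known or untested is meant among the compounds shown, and "the series" means these compounds.

Of the compounds shown here, three built on the shared core have so far been read in an ADME assay on HEL cells (Homo sapiens) for cytotoxicity, read by microscopy; on this read-out higher numbers stand for lower toxicity in this test and lower numbers for higher toxicity in this test. Compound 1 `Cc1ccccc1OCCCCCn1ccc(=O)[nH]c1=O` returns only a limit in this assay, > 100000 nM. Compound 3 `Cc1cn(CCCCCOc2ccc(Br)cc2)c(=O)[nH]c1=O` gives 100000 nM, while compound 2 `O=c1ccn(CCCCCOc2ccc([N+](=O)[O-])cc2)c(=O)[nH]1` gives 20000 nM. Of the two actual numbers, compound 2 stands lowest; compound 3 sits above it by a margin that lies beyond the usual scatter, and the third value is a limit rather than a number.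

Compound 4 `CC(C)(C)c1ccc(OCCCCCn2ccc(=O)[nH]c2=O)cc1` has not been measured. It differs from compound 2 in one place: tert-butyl in place of nitro on an aromatic carbon. For the measured compounds named here, no step between measured compounds matches this change, so the expectation rests on the wider picture. Compound 1, which also carries no nitro, gives only a limit, > 100000 nM. On that basis the step from compound 2 to compound 4 is expected to be upward and beyond the scatter, as a 5.0-fold higher number from compound 2 to compound 4 (0.70 log units; beyond the scatter). Compound 4 is therefore estimated at 100000 nM, within a range from 30000 nM to 200000 nM.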

Compound 4, minimum cytotoxic concentration: 100000 nM
Beside the measured number, compound 4's estimate shows no gap at the digits printed; the range from low to high includes it.
By their numbers in this assay, from the lowest: compound 2; then compounds 3 and 4 (each within the scatter of the next).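

In this assay, tert-butyl in place of nitro on an aromatic carbon gives a 5.0-fold higher number from compound 2 to compound 4 (0.70 log units; beyond the scatter), the only step shown between two measured compounds that differ in one place. Until now, the lower number of compound 2 could be set only against compounds that differ from it in more than one place; this pair ties that gap to a single change at this position. For the compounds shown here, the upper end of the read-out also comes into view, with compound 1 as the one compound that returns a limit rather than a number: the limit of > 100000 nM in this assay, at which 1 of the 4 values shown sits.

A single pair cannot separate what the departure of nitro contributes from what the arrival of tert-butyl contributes. The compounds shown also leave open how an amine or a carboxylic acid at this position would read.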